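Swapping Nitro for Trifluoromethoxy on the Sulfonyl Ring

This account rests on a few compounds, and the source may have more. Where it says the series, first, only, none or still open, it means among the compounds named here.

Compound 1 `O=C1C=CC2(C=C1)OCC(=O)N2S(=O)(=O)c1ccccc1`: in a functional assay on HepG2 cells (Homo sapiens) for inhibition, read by sulforhodamine B assay, with a stated time of 74 h (on this read-out higher numbers stand for weaker inhibition and lower numbers for stronger inhibition), compound 1 gives only a limit, > 10000 nM.
Compound 2 `Cc1ccccc1S(=O)(=O)N1C(=O)COC12C=CC(=O)C=C2`: in this assay compound 2 gives 750 nM.
Compound 3 `O=C1C=CC2(C=C1)OCC(=O)N2S(=O)(=O)c1ccc([N+](=O)[O-])cc1`: in this assay compound 3 gives only a limit, > 10000 nM.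

Compound 3 stands at the limit of > 10000 nM in this assay, at which 2 of the 3 values shown sit, so its own number is not known. Compound 4 `O=C1C=CC2(C=C1)OCC(=O)N2S(=O)(=O)c1ccc(OC(F)(F)F)cc1` differs from compound 3 by trifluoromethoxy in place of nitro on an aromatic carbon. For the measured compounds named here, no measured step covers this exchange directly. Going by the values given here, the step that the two limits leave unreadable from compound 1 to compound 3 cannot be read, and the only readable step, an at least 13-fold lower number from compound 1 to compound 2 (1.12 log units; beyond the scatter), concerns methyl at a different place on the ring. With nothing to anchor it, the expectation for compound 4 stays close to the limit. Compound 4 is expected to give 8000 nM, within 1500 nM to 30000 nM. This corresponds to an estimated at least 1.2-fold lower number from compound 3 to compound 4 (0.09 log units; that floor lies within the scatter).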

Compound 4, half-maximal inhibitory concentration: > 10000 nM
Compound 4: no number, only a limit; the forecaster's own chance of this, stated with the estimate: 55%; middle value at least 1.2-fold (0.09 log units) away from the limit.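

Compound 4, like compound 1 and compound 3, gives only a limit in this assay, so no new step between these compounds can be read: the limit of > 10000 nM in this assay, at which 3 of the 4 values shown sit.

The compounds shown leave open whether trifluoromethoxy and nitro differ at all in their effect, and where the true numbers of compound 3 and compound 4 lie.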